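The compounds below may be only part of what the source reports. "The series", "measured", "known", "first", "only" and "open" are said of these compounds alone.

In an ADME assay on liver (Homo sapiens) for metabolic stability, using microsomes (a higher number here means that the compound lasts longer, a lower number that the compound disappears faster), compound 1 (`CN1Cc2cc(ccc2S(=O)(=O)C2CC2)NC(=O)CCc2cc(ccc2OCC2CC2)[C@@H](Nc2ccc3c(N)ncc(F)c3c2)C1=O`) gives 0.383 h, compound 2 (`CN1Cc2cc(ccc2S(=O)(=O)C2CC2)NC(=O)CCc2cccc(c2)[C@@H](Nc2ccc3c(N)ncc(F)c3c2)C1=O`) gives 0.217 h and compound 3 (`CN1Cc2cc(ccc2S(=O)(=O)C2CC2)NC(=O)N(CC2CC2)CCc2cccc(c2)C(Nc2ccc3c(N)ncc(F)c3c2)C1=O`) gives 0.0833 h. Compound 2 thus stands within the scatter of compound 1, while compound 3 lies lower than compound 2 by more than the scatter.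

The unmeasured compound 4 (`COc1cc2cc(c1)[C@@H](Nc1ccc3c(N)ncc(F)c3c1)C(=O)N(C)Cc1cc(ccc1S(=O)(=O)C1CC1)NC(=O)CC2`) departs from compound 2 in one place, with methoxy in place of hydrogen on an aromatic carbon. That carbon belongs to a six-membered aromatic ring of carbon only, and the new group is meta to two fused rings.

Within the data shown here, only one measured step bears on this change. It exchanges cyclopropylmethoxy for hydrogen on an aromatic carbon and amounts to a 1.8-fold lower number from compound 1 to compound 2 (0.25 log units; within the scatter). That step involves a different group, runs in the opposite sense and stays within the scatter. Among the measured compounds shown here, compound 3 differs from the others in more than one place and offers no single-place comparison, and no compound with methoxy has yet been measured. A small rise at most is therefore expected in this assay, with nothing beyond the scatter. The expected step is a 1.1-fold higher number from compound 2 to compound 4 (0.04 log units; within the scatter). Compound 4 is estimated at 0.24 h, with an expected range from 0.11 h to 0.5 h.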

Compound 4, half-life: 0.25 h
The estimate for compound 4 lay 1.0-fold (0.02 log units) below the measured number; low and high end bracket the measured number.
By their numbers in this assay, from the lowest: compound 3; then compounds 2, 4 and 1 (each within the scatter of the next).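

Methoxy in place of hydrogen on this aromatic carbon, which belongs to a six-membered aromatic ring of carbon only within a fused or bridged system of three rings, gives a 1.2-fold higher number from compound 2 to compound 4 (0.06 log units; within the scatter) in this assay, so this position now has a direct single-place reading for this group rather than an inference from a different one. Together with a 1.8-fold lower number from compound 1 to compound 2 (0.25 log units; within the scatter), which involves cyclopropylmethoxy, it means that neither single-place change among the compounds shown moves the number beyond the scatter, and compound 4 adds the first case in which a group enters compound 2 rather than leaves compound 1. Nothing measured here gives a reason for the size of this step.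

The compounds shown leave open whether a larger or differently charged group on this same carbon, such as an amine, a carboxylic acid or a longer chain like butoxy, would also stay within the scatter of compound 2. They also leave open whether methoxy on another carbon of this ring would give a similar reading in this assay.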